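Replacing 2-fluorobenzyl with methyl: compound 3 to compound 4

The compounds below may be only part of what the source reports. "The series", "measured", "known", "first", "only" and "open" are said of these compounds alone.

In a functional assay on RAW264.7 cells (Mus musculus) for inhibition, read by Griess assay, with stated times of 2 h and 24 h (on this read-out lower numbers stand for stronger inhibition and higher numbers for weaker inhibition), compound 3 (`COc1ccc([C@@H]2CC(=O)c3c(O)cc(OCc4cn(Cc5ccccc5F)nn4)cc3O2)cc1O`) gives 7320 nM. This is within the scatter of compound 2 (`COc1ccc([C@@H]2CC(=O)c3c(O)cc(OCc4cn(Cc5ccccc5C(F)(F)F)nn4)cc3O2)cc1O`) at 12500 nM, while compound 1 (`C#CCOc1cc(O)c2c(c1)O[C@H](c1ccc(OC)c(O)c1)CC2=O`) at 20900 nM stands higher, beyond the scatter.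

The change under consideration leads to compound 4 (`COc1ccc([C@@H]2CC(=O)c3c(O)cc(OCc4cn(C)nn4)cc3O2)cc1O`): hydrogen in place of 2-fluorophenyl on a saturated chain carbon bound to an aromatic nitrogen. This is hydrogen in place of 2-fluorophenyl on a saturated chain carbon bound to an aromatic nitrogen, or 2-fluorobenzyl to methyl when cut one bond further out.

Going by the values given here, only one measured step bears on it closely: a 1.7-fold lower number from compound 2 to compound 3 (0.23 log units; within the scatter), a swap of fluoro for trifluoromethyl that keeps the aromatic ring. Among the compounds with values here, no measured step removes that ring, so the evidence is thin. Compound 1, which also has no 2-fluorobenzyl group, gives 20900 nM, and this points towards a higher number in this assay. The expected change is modest, only slightly beyond the scatter: a 2.2-fold higher number from compound 3 to compound 4 (0.34 log units; beyond the scatter). For compound 4 the estimated value is 16000 nM, with an expected range of 6500 nM to 40000 nM.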

Compound 4, half-maximal inhibitory concentration: 15200 nM
Beside the measured number, compound 4's estimate is 1.1-fold (0.02 log units) above it, and the stated range covers the measured number.
By their numbers in this assay, from the lowest: compounds 3, 2, 4 and 1 (each within the scatter of the next, the first and the last beyond it).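

In this assay, cutting 2-fluorobenzyl back to methyl gives a 2.1-fold higher number from compound 3 to compound 4 (0.32 log units; beyond the scatter), the first sign that losing 2-fluorophenyl at this position has a modest cost. The same cut on the 2-(trifluoromethyl)phenyl side gives a 1.2-fold higher number from compound 2 to compound 4 (0.08 log units; within the scatter), and 1-methyl-1H-1,2,3-triazol-4-yl in place of ethynyl gives a 1.4-fold lower number from compound 1 to compound 4 (0.14 log units; within the scatter), so among these steps only the one from the 2-fluorobenzyl compound lies beyond the scatter, and the methyl group alone does not separate compound 4 from compound 1. Nothing measured here bears on the reason for this result.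

Still open, from the compounds shown here alone, is how an unsubstituted benzyl, a longer chain such as 2-phenylethyl, or a chain ending in an amine or a carboxylic acid would read in this place. Also open, going by these compounds, is whether any group here can reach a number clearly lower than that of compound 3.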